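Sulfur-linked dichlorophenyl variant of a diamino quinoxaline core

The source may hold more compounds than are shown below. What is called first, only, known or untested is meant among the compounds shown, and "the series" means these compounds.

Measured compounds:
Compound 1, `Nc1cc(N)c2nc(-c3ccccc3)c(NCc3ccc(Cl)c(Cl)c3)nc2c1`, 6920 nM
Compound 2, `Nc1cc(N)c2nc(-c3ccccc3)c(Sc3ccc(F)cc3)nc2c1`, 33900 nM
Compound 3, `COc1cc(CNc2nc3cc(N)cc(N)c3nc2-c2ccccc2)cc(OC)c1OC`, 3390 nM

The three compounds share one core and were tested in a functional assay on OVCAR-3 cells (Homo sapiens) for inhibition, read by sulforhodamine B assay, with a stated time of 48 h; on this read-out lower numbers stand for stronger inhibition of growth and higher numbers for weaker inhibition of growth. Compound 2, the only one in which the side group is joined through a sulfur, stands at the highest number of the three; compound 1 sits well below it, and compound 3 lies furthest from it, both gaps beyond the scatter.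

Compound 4, `Nc1cc(N)c2nc(-c3ccccc3)c(Sc3ccc(Cl)c(Cl)c3)nc2c1`, has not yet been measured. It differs from compound 2 in one place: 3,4-dichlorophenyl in place of 4-fluorophenyl on a sulfur. The 3,4-dichlorophenyl pattern recurs in compound 1, where it sits on a different linker and accompanies a lower number than compound 2 shows. For the measured compounds named here, no step between measured compounds isolates the change from compound 2 to compound 4, so the expectation rests on that loose comparison alone. Compound 4 is expected to give 18000 nM in this assay, within 5000 nM to 60000 nM. The estimated step of a 1.9-fold lower number from compound 2 to compound 4 (0.27 log units; within the scatter) is a modest move toward a lower number, not clearly beyond the scatter.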

Compound 4, concentration for total growth inhibition: 46800 nM
Beside the measured number, compound 4's estimate is 2.6-fold (0.41 log units) below it; low and high end bracket the measured number.
By their numbers in this assay, from the lowest: compound 3; then compound 1; then compounds 2 and 4 (each within the scatter of the next).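

In this assay, for the compounds shown here, 3,4-dichlorophenyl in place of 4-fluorophenyl on a sulfur gives a 1.4-fold higher number from compound 2 to compound 4 (0.14 log units; within the scatter), the first direct reading at this position, and it leaves the two groups indistinguishable. The 3,4-dichlorophenyl group also does not bring the number of compound 1 with it: on its different linker, compound 1 gives 6920 nM, whereas on a sulfur, compound 4 gives 46800 nM. Nothing available explains why the two sulfur-linked groups read alike.

The compounds shown leave open whether a phenyl ring on the sulfur carrying an amine or a carboxylic acid, or a plain methyl on the sulfur, would move the number beyond the scatter. They also leave open how a sulfone in place of the sulfur would read.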